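Exchanging the Pendant Aryl Group While Cytotoxicity Stays Unmeasurable

The source may report more compounds than this note shows. Statements on the series, on what has been measured and on what is new or still open speak of the compounds shown alone.

Compound 1, `CC(C)N(Cc1cccc(OCCCCCC(=O)O)c1)C(=O)c1ccc(-c2cccc(N(C)C)c2)cc1`, in an ADME assay on HEK293 cells (Homo sapiens) for cytotoxicity, read by CellTiter-Glo and resazurin assay, with a stated time of 72 h (a higher number here means that more compound is needed for the effect, a lower number that less compound is needed), gives > 26000 nM, which is a limit of the assay and not a number.
Compound 2, `CC(C)N(Cc1cccc(OCCCCCC(=O)O)c1)C(=O)c1ccc(-c2ccoc2)cc1`, in this assay gives > 26000 nM, again a limit rather than a number.

Both measured values sit at the limit of > 26000 nM in this assay, at which 2 of the 2 values shown sit, so the step that the two limits leave unreadable from compound 1 to compound 2 cannot be read in size or direction. Compound 2 therefore stands only at a limit, with no number of its own to compare against.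

Compound 3, `COc1cccc(-c2ccc(C(=O)N(Cc3cccc(OCCCCCC(=O)O)c3)C(C)C)cc2)c1`, arises from compound 2 by 3-methoxyphenyl in place of furan-3-yl on an aromatic carbon. Going by the values given here, the only measured step touches the same position, but its size is hidden by the two limits, so no size of step in this assay can be taken from it; what is seen is simply that both groups placed there left the value at the limit. Compound 3 is therefore expected to remain at or beyond that limit as well, an expected step that the limit leaves unreadable from compound 2 to compound 3. The estimate for compound 3 in this assay is 40000 nM, between 20000 nM and 120000 nM.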

Compound 3, half-maximal effective concentration: > 20900 nM
Compound 3 was reported as a limit (the forecaster's own chance of this, stated with the estimate: 80%); the middle value does not contradict the limit.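

Going by these compounds alone, compound 1, compound 2 and compound 3 all stand only as limits in this assay, so no step among them can be read in size or direction. From the compounds shown here alone, how the three truly compare, and whether any group at this position gives a measurable cytotoxic concentration, remains open.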